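Ester-bearing triazole series: aromatic carbon substituent, growth inhibition

The source may hold more compounds than are shown below. What is called first, only, known or untested is meant among the compounds shown, and "the series" means these compounds.

Measured compounds:
compound 1 `COC(=O)c1nc(C)n(-c2cccc(Br)c2)n1`, 7350 nM
compound 2 `COC(=O)c1nc(C)n(-c2ccc(C(F)(F)F)cc2)n1`, 16600 nM
compound 3 `CCc1nc(C(=O)OC)nn1-c1ccc(F)cc1`, 71300 nM

In a functional assay on NCI-H226 cells (Homo sapiens) for inhibition, read by MTT assay, with a stated time of 72 h (a lower number here means a stronger inhibitor of growth, a higher number a weaker inhibitor of growth), compound 3 gives 71300 nM, the highest of the three numbers; the nearest is compound 2 at 16600 nM, a gap beyond the scatter, and the furthest is compound 1 at 7350 nM. Compound 3 thus stands as the weakest growth inhibitor of the set so far. Compound 4 `COC(=O)c1nc(C2CCCC2)n(-c2ccc(F)cc2)n1` differs from compound 3 by cyclopentyl in place of ethyl on an aromatic carbon. Among the measured compounds shown here, no measured pair in the set shares this change, so its size is unknown. Compound 4 is expected to give 40000 nM, within 8000 nM to 150000 nM. The estimated step of a 1.8-fold lower number from compound 3 to compound 4 (0.25 log units; within the scatter) is expected to be small and toward a lower number, possibly within the scatter.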

Compound 4, concentration for 50% growth inhibition: 70500 nM
Compound 4: middle estimate off by 1.8-fold (0.25 log units), on the low side; measured number inside the range.
By their numbers in this assay, from the lowest: compound 1; then compound 2; then compounds 4 and 3 (each within the scatter of the next).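

Cyclopentyl in place of ethyl on an aromatic carbon between two ring nitrogen atoms gives a 1.0-fold lower number from compound 3 to compound 4 (0.00 log units; within the scatter) in this assay. At this position, then, an open chain and a five-membered carbon ring read alike, although this rests on a single pair. Nothing on hand gives a reason for this result. On these data alone, whether an amine or a longer chain at this position would shift the number remains open. Also open, as far as these compounds go, is whether this swap reads the same alongside the other aromatic groups of compound 1 and compound 2.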